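Chloro to fluoro on the aromatic ring of compound 2

The compounds below may be only part of what the source reports. "The series", "measured", "known", "first", "only" and "open" are said of these compounds alone.

Measured in a physicochemical assay for lipophilicity; a lower number here means a more polar compound, a higher number a more lipophilic compound:
- compound 1 `COc1ccc(C2C[C@@]3(ON2c2ccccc2)C(=O)O[C@@H]2[C@H]3CC[C@H](C)[C@]3(O)C=CC(=O)[C@@]23C)cc1` gives 3.25
- compound 2 `C[C@H]1CC[C@@H]2[C@@H](OC(=O)[C@]23CC(c2cccc(Cl)c2)N(c2ccccc2)O3)[C@]2(C)C(=O)C=C[C@@]12O` gives 3.87

Of these two, compound 2 stands highest at 3.87. Compound 3 `C[C@H]1CC[C@@H]2[C@@H](OC(=O)[C@]23CC(c2cccc(F)c2)N(c2ccccc2)O3)[C@]2(C)C(=O)C=C[C@@]12O` departs from it by one change: fluoro in place of chloro on an aromatic carbon. For the measured compounds named here, no measured step makes this exchange. The nearest evidence is a number 0.62 log units higher from compound 1 to compound 2 (beyond the scatter), a different exchange that gives only a rough scale. A somewhat smaller, downward step in this assay is expected. The expected step is a number 0.47 log units lower from compound 2 to compound 3 (beyond the scatter). Compound 3 is estimated at 3.4, with an expected range of 3.05 to 3.75.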

Compound 3, partition coefficient: 3.35
Beside the measured number, compound 3's estimate is 0.05 log units above it, and the stated range covers the measured number.
By their numbers in this assay, from the lowest: compounds 1 and 3 (each within the scatter of the next); then compound 2.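

In this assay the halogen on this aromatic carbon counts, with a number 0.52 log units lower from compound 2 to compound 3 (beyond the scatter) for fluoro in place of chloro. Against 4-methoxyphenyl on the saturated ring carbon, 3-fluorophenyl gives a number 0.10 log units higher from compound 1 to compound 3 (within the scatter) and the two groups are not separated, while 3-chlorophenyl stands apart from both. No measurement at hand gives a reason for these steps. Open, from the compounds shown here alone, are where a nitrile or an amine on this aromatic carbon would fall in this assay and whether the chloro to fluoro step keeps its size with another group elsewhere on the shared core.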